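The compounds below may be only part of what the source reports. "The series", "measured", "known", "first", "only" and "open" are said of these compounds alone.

Measured so far in an ADME assay on MT4 cells (Homo sapiens) for cytotoxicity, read by MTT assay, with a stated time of 5 days; on this read-out higher numbers stand for lower toxicity in this test and lower numbers for higher toxicity in this test:
- compound 1 `Cc1cc(C)c(Nc2nc(NCCn3ccc(=O)[nH]c3=O)ncc2[N+](=O)[O-])c(C)c1` gives >= 3330 nM, which is a limit of the test rather than a number.
- compound 2 `Cc1cc(/C=C/C#N)cc(C)c1Oc1cc(Cl)nc(NCCn2ccc(=O)[nH]c2=O)n1` gives > 284000 nM, also a limit.
- compound 3 `Cc1cc(C)c(Oc2ccnc(NCCn3ccc(=O)[nH]c3=O)n2)c(C)c1` gives 272000 nM.

Compound 1 therefore has no exact value in this assay: the test reports only a limit for it, and of the three values shown, one further value is a limit as well (the limit of > 284000 nM in this assay, at which 1 of the 3 values shown sits). The limit for compound 1 (the limit of >= 3330 nM in this assay, at which 1 of the 3 values shown sits) sits far from the other two values, so compound 1 cannot be placed against compound 2 or compound 3 with any confidence.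

Compound 4 `Cc1cc(C)c(Nc2nc(NCCn3ccc(=O)[nH]c3=O)ncc2N)c(C)c1` has not been measured yet. It differs from compound 1 in one place: amino in place of nitro on an aromatic carbon. Among the compounds with values here, no pair of measured compounds differs by this same change, so the size of the step has to be guessed. Given that compound 1 itself is known only as a limit, the expected step from compound 1 to compound 4 is modest, a step that the limit leaves unreadable from compound 1 to compound 4, with the expectation of no movement beyond the usual scatter. On that basis compound 4 is estimated at 30000 nM in this assay, with a likely range from 3300 nM to 300000 nM.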

Compound 4, half-maximal cytotoxic concentration: > 199000 nM
Compound 4: only a limit was reported; the forecaster's own chance of this, stated with the estimate: 40%; middle value at least 6.6-fold (0.82 log units) from the limit.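

In this assay compound 1 gives >= 3330 nM, which is a limit. Compound 4 gives > 199000 nM, which is also a limit. Within the data shown here, with only these two limits, no step from compound 1 to compound 4 can be read. The compounds shown leave open how large a change amino in place of nitro on an aromatic carbon brings in this assay, and in which direction.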